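A Pyridinylmethyl Group in Place of the Aryl Group

The source may report more compounds than this note shows. Statements on the series, on what has been measured and on what is new or still open speak of the compounds shown alone.

In a functional assay on HeLa cells (Homo sapiens) for antiproliferative activity, read by CCK-8 assay, with a stated time of 72 h, tested at 2 uM (on this read-out higher numbers stand for a stronger effect at the one concentration tested and lower numbers for a weaker effect), compound 2 `Cc1ccc(N2CCN(C(=S)SCc3ccc(C(=O)Nc4ccccc4N)cc3)CC2)cc1` gives 25.3%, the lower of the two measured numbers, while compound 1 `Nc1ccccc1NC(=O)c1ccc(CSC(=S)N2CCN(c3ccc(Cl)cc3)CC2)cc1` gives 51.2%. Going by the values given here, the single measured step, a number 25.9 percentage points lower from compound 1 to compound 2 (beyond the scatter), concerns a substituent on the aromatic ring and does not bear directly on the change to compound 3 `Nc1ccccc1NC(=O)c1ccc(CSC(=S)N2CCN(Cc3cccnc3)CC2)cc1`, which carries (pyridin-3-yl)methyl in place of 4-methylphenyl on an amine nitrogen in a ring. Among the compounds with values here, no step of this kind has been measured, so the direction is open; the measured pair shows only that changes at this end of the molecule can move the read-out by a modest amount. Compound 3 is therefore estimated at 35%, within 15% to 60%, an expected step of a number 9.7 percentage points higher from compound 2 to compound 3 (within the scatter).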

Compound 3, a percentage reported as inhibition, at one concentration (the size of the read-out at that concentration, not a potency): 69.7%
The estimate for compound 3 lay 34.7 percentage points below the measured number; measured number outside the range, above it.
By their numbers in this assay, from the lowest: compound 2; then compound 1; then compound 3.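

In this assay, replacing the aryl group on the amine nitrogen with (pyridin-3-yl)methyl gives a number 44.4 percentage points higher from compound 2 to compound 3 (beyond the scatter), and the same replacement for 4-chlorophenyl gives a number 18.5 percentage points higher from compound 1 to compound 3 (beyond the scatter). This position therefore accepts a group other than a substituted phenyl ring, and the read-out rises against both earlier compounds. No evidence is available to explain this rise.

The change brings in the ring nitrogen and the carbon link together, and the compounds shown cannot separate the two. A benzyl group on the same nitrogen would keep the link without the ring nitrogen.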